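Double-bond geometry in the silyl ether series

The compounds below may be only part of what the source reports. "The series", "measured", "known", "first", "only" and "open" are said of these compounds alone.

Values in a functional assay on A2780 cells (Homo sapiens) for antiproliferative activity, read by sulforhodamine B assay, with a stated time of 48 h; a higher number here means a weaker inhibitor of growth, a lower number a stronger inhibitor of growth:
Compound 1 `CC(C)(C)[Si](C)(C)OC[C@H]1OCCC[C@H]1O[Si](C)(C)C(C)(C)C`: > 100000 nM (a limit, not a number)
Compound 2 `CC(C)(C)[Si](C)(C)O[C@@H]1CCCO[C@@H]1/C=C/C(=O)OCc1ccccc1`: 32000 nM
Compound 3 `O=C(/C=C/[C@H]1OCCC[C@H]1O)OCc1ccccc1`: > 100000 nM (a limit, not a number)

Among the measured compounds shown here, compound 2 is the only member of the set with a true number. The other readings amount to the limit of > 100000 nM in this assay, at which 2 of the 3 values shown sit.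

Compound 4 `CC(C)(C)[Si](C)(C)O[C@@H]1CCCO[C@@H]1/C=C\C(=O)OCc1ccccc1` is compared directly with compound 2: the two compounds have the same atoms and bonds and differ only in configuration as drawn: 1 of 3 stereo elements differ; a double bond is drawn E in compound 2 and Z in compound 4. The double bond is therefore the only point of interest, and the ester and the protected oxygen stay as they are.

For the measured compounds named here, only one measured step bears on this, and only indirectly: an at least 3.1-fold higher number from compound 2 to compound 3 (0.49 log units; beyond the scatter). That step removes a group that compound 4 keeps, so it says nothing about double-bond geometry. Going by the values given here, no measured pair changes that configuration.

With no such evidence, the expectation in this assay is for no step beyond the scatter, with a slight lean towards weaker growth inhibition. Compound 2, at 32000 nM, is the only anchor for this estimate. A reported limit remains possible for compound 4.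

The expected step is a 1.3-fold higher number from compound 2 to compound 4 (0.10 log units; within the scatter).

For compound 4 the estimated value is 40000 nM, with an expected range of 15000 nM to 100000 nM.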

Compound 4, concentration for 50% growth inhibition: 29000 nM
Compound 4: the middle estimate sits 1.4-fold (0.14 log units) above what was measured; measured number inside the range.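

Working notes on the silyl ether series. In this assay, the E and Z forms of the double bond now have a direct comparison: a 1.1-fold lower number from compound 2 to compound 4 (0.04 log units; within the scatter). So, with the silyl ether and the benzyl ester kept in place, the drawn geometry of this double bond makes no difference beyond the scatter, a point that the earlier step, an at least 3.1-fold higher number from compound 2 to compound 3 (0.49 log units; beyond the scatter), could not address because it concerned removal of the silyl group rather than geometry. The comparison isolates this single feature, and its reading rests on one point: the fact that compounds 2 and 4 differ only in the configuration as drawn

The compounds shown do not include a Z double bond paired with a free hydroxyl, so it remains open whether geometry has any bearing on the reading once the silyl group is gone. Also open, from the compounds shown here alone, is how this assay would respond to a carboxylic acid or an amide in place of the benzyl ester, or to a saturated chain in place of the double bond.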